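The compounds below may be only part of what the source reports. "The series", "measured", "known", "first", "only" and "open" are said of these compounds alone.

In a functional assay on ECa-109 cells for inhibition, with ECa-109 cell line (Homo sapiens) as the target, read by sulforhodamine B assay (on this read-out higher numbers stand for weaker inhibition and lower numbers for stronger inhibition), compound 1 `O=C1C(Nc2ccccc2)=CC(=O)c2c1nc1n2[C@H]2OC[C@@H](O)[C@H]2OC1`, with phenyl on the amine nitrogen, gives 3560 nM. Compound 2 `O=C1C(NC2CCCC2)=CC(=O)c2c1nc1n2[C@H]2OC[C@@H](O)[C@H]2OC1`, with cyclopentyl there, stands at > 16000 nM, which is a limit of the assay and not a number. The next change leads to compound 3 `CCc1ccc(NC2=CC(=O)c3c(nc4n3[C@H]3OC[C@@H](O)[C@H]3OC4)C2=O)cc1`: 4-ethylphenyl in place of cyclopentyl on an amine nitrogen. Going by the values given here, the one measured step bearing on this is an at least 4.4-fold higher number from compound 1 to compound 2 (0.65 log units; beyond the scatter), which lies beyond the scatter. Read in reverse, that step suggests a lower number in this assay of similar size for compound 3, which again carries a six-membered aromatic ring of carbon only. Among the compounds with values here, no measured step covers the ethyl group, so the range stays wide. The expected step is an at least 4.0-fold lower number from compound 2 to compound 3 (0.60 log units; beyond the scatter). For compound 3 the estimate is 4000 nM, with an expected range of 1500 nM to 12000 nM.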

Compound 3, half-maximal inhibitory concentration: > 4000 nM
Compound 3: only a limit was reported (the forecaster's own chance of this, stated with the estimate: 12%); the middle value lies on the limit itself.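

In this assay compound 3 gives > 4000 nM, which is a limit of the assay and not a number. Ethyl in place of hydrogen on an aromatic carbon is read only as a floor, an at least 1.1-fold higher number from compound 1 to compound 3 (0.05 log units; that floor lies within the scatter), so this position shows no gain from the ethyl group, and how much weaker compound 3 may be stays unknown. The step between compound 2 and compound 3 cannot be read, as both ends are limits, so the lower number seen for phenyl over cyclopentyl does not carry over to 4-ethylphenyl.

Open, as far as these compounds go, is the true value of compound 3 and whether any group on the phenyl ring improves on hydrogen. A methoxy group, a chlorine atom or a smaller methyl group in place of the ethyl would test this.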